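This account rests on a few compounds, and the source may have more. Where it says the series, first, only, none or still open, it means among the compounds named here.

In a toxicity assay on CCRF-CEM cells (Homo sapiens) for cytotoxicity (a higher number here means that more compound is tolerated, a lower number that less compound is tolerated), compound 3 `Fc1cccc(F)c1Cn1c(-c2c(F)cccc2F)nc2c(CCl)cccc21` gives 13.4 uM, the lowest of the three numbers shown, although its gap to compound 1 `CCc1cccc2c1nc(-c1c(F)cccc1F)n2Cc1c(F)cccc1F`, which gives 26.1 uM, lies within the scatter. Compound 2 `CC(=O)Nc1cccc2c1nc(-c1c(F)cccc1F)n2Cc1c(F)cccc1F` gives 39.3 uM. Compound 4 `[N-]=[N+]=NCc1cccc2c1nc(-c1c(F)cccc1F)n2Cc1c(F)cccc1F` carries azido in place of chloro on a saturated chain carbon bound to an aromatic carbon. For the measured compounds named here, two measured steps bear on this change: a 1.9-fold lower number from compound 1 to compound 3 (0.29 log units; within the scatter), which swapped groups on the same saturated chain carbon, and a 2.9-fold lower number from compound 2 to compound 3 (0.47 log units; beyond the scatter), which is modest. Both are small, so only a small move in this assay is expected for compound 4, with no strong direction. Compound 4 is therefore estimated at 18 uM, in the range 8 uM to 40 uM, meaning an expected step of a 1.3-fold higher number from compound 3 to compound 4 (0.13 log units; within the scatter).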

Compound 4, half-maximal toxic concentration: > 100 uM
Compound 4 gave a limit, no number; the forecaster's own chance of this, stated with the estimate: 5%; middle value at least 5.5-fold (0.74 log units) from the limit.
By their numbers in this assay, from the lowest: compounds 3, 1 and 2 (each within the scatter of the next, the first and the last beyond it). At a limit, above all of these: compound 4.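

In this assay compound 4 stands at a limit of the assay and not at a number: the limit of > 100 uM in this assay, at which 1 of the 4 values shown sits. On the saturated chain carbon bound to an aromatic carbon, azido sets itself apart from chloro, with an at least 7.4-fold higher number from compound 3 to compound 4 (0.87 log units; beyond the scatter), and from methyl, with an at least 3.8-fold higher number from compound 1 to compound 4 (0.58 log units; beyond the scatter), whereas the change from methyl to chloro there stayed within the scatter. Azidomethyl also clears acetamido on the aromatic carbon, with an at least 2.5-fold higher number from compound 2 to compound 4 (0.40 log units; beyond the scatter). From the compounds shown here alone, the actual value of compound 4 stays open. So does the reading for an amine in place of azido on that saturated chain carbon.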